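The compounds below may be only part of what the source reports. "The series", "measured", "known", "first", "only" and "open" are said of these compounds alone.

Measured in a functional assay on MCF7 cells (Homo sapiens) for cytotoxicity, read by colorimetric assay and MTT assay; a higher number here means a weaker inhibitor, a lower number a stronger inhibitor:
compound 1 `COc1ccc(-c2cc3cccc(OC)c3nc2O)cc1`: 10000 nM
compound 2 `COc1cc(OC)c2cc(-c3ccc(OCc4ccccc4)cc3)c(O)nc2c1`: 10000 nM
compound 3 `COc1ccc(-c2cc3c(OC)cc(OC)cc3n(CC#N)c2=O)cc1`: 10000 nM

In this assay, compound 3 stands level with compound 1 and compound 2. The three values do not differ at the digits given, so none of the compounds ranks ahead of the others.

Compound 4 `COC(=O)CCn1c(=O)c(-c2ccc(OC)cc2)cc2c(OC)cc(OC)cc21` keeps the core of compound 3 and changes one group: (methoxycarbonyl)methyl in place of cyano on a saturated chain carbon bound to an aromatic nitrogen. Here (methoxycarbonyl)methyl takes the place of cyano on a saturated chain carbon bound to an aromatic nitrogen. Cut one bond further out, the same difference reads cyanomethyl to 2-(methoxycarbonyl)ethyl.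

Among the measured compounds shown here, no two measured compounds differ in only one place, so the data offer no direct guide to this change. For the measured compounds named here, the only anchor is that compound 3 gives 10000 nM, so no step beyond the scatter is expected, in either direction. The expected step is no change at the digits printed from compound 3 to compound 4 (within the scatter). For compound 4 the estimated value is 10000 nM, with an expected range from 5000 nM to 20000 nM.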

Compound 4, half-maximal inhibitory concentration: 10000 nM
Estimate against measurement, compound 4: no gap at the digits printed; the range from low to high includes it.
By their numbers in this assay, from the lowest: compounds 1, 2, 3 and 4 (each within the scatter of the next).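

Among the compounds shown here, compound 3 and compound 4 are the first pair here that differ in one place, giving a first direct reading of a change on the saturated chain carbon bound to an aromatic nitrogen. In this assay, replacing cyano with the larger (methoxycarbonyl)methyl, which adds one hydrogen-bond acceptor and swaps a triple bond for a double bond, gives no change at the digits printed from compound 3 to compound 4 (within the scatter) and so leaves this read-out unmoved. No supporting measurement is available to explain this result.

Going by these compounds, all four compounds stand level, so it remains open whether any group at this place can shift the value. For the compounds shown here, whether a carboxylic acid or an amine at the end of this chain would give a different reading is a question the single pair cannot settle.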